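Ester, amide and ethoxymethyl on the shared core

A few compounds are considered here, and "the series" means these few. Any claim that something is new, unique, unknown or untested is made for them only; others in the source may bear on it.

compound 1 `CCc1cccc2c(OC)c(-c3occ(C)c3C(=O)OC)ccc12`: 1.3 ug/mL
compound 2 `CCc1cccc2c(OC)c(-c3occ(C)c3C(=O)NC)ccc12`: > 10 ug/mL

In a functional assay on KBVIN cells (Homo sapiens) for cytotoxicity, read by MTT assay, with a stated time of 72 h (on this read-out lower numbers stand for an effect already at smaller amounts and higher numbers for an effect only at larger amounts of compound), compound 1 gives 1.3 ug/mL. Compound 2 reaches only > 10 ug/mL, which is a limit of the assay and not a number. Going by the values given here, the one measured step, an at least 7.6-fold higher number from compound 1 to compound 2 (0.88 log units; beyond the scatter), is thus known only as a lower bound; it rests on (the limit of > 10 ug/mL in this assay, at which 1 of the 2 values shown sits). On the numbers shown compound 2 stands at the top end of this assay, the weaker of the two measured compounds.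

Compound 3 `CCOCc1c(C)coc1-c1ccc2c(CC)cccc2c1OC` carries ethoxymethyl in place of methylcarbamoyl on an aromatic carbon. Among the compounds with values here, the only measured step concerns the same carbon of the five-membered aromatic ring, but it exchanged one carbonyl substituent for another, whereas here the carbonyl and the hydrogen-bond donor both leave and an ether chain enters. Compound 1, the compound without a hydrogen-bond donor at this position, is the more potent of the pair. Within the data shown here, on that basis compound 3 is expected to show an at least 2.0-fold lower number from compound 2 to compound 3 (0.30 log units; that floor lies within the scatter), with wide uncertainty since no measured step removes the carbonyl. Compound 3 is therefore estimated at 5 ug/mL, within 1.5 ug/mL to 20 ug/mL.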

Compound 3, concentration for half-maximal effect: > 10 ug/mL
Compound 3 was reported as a limit; the forecaster's own chance of this, stated with the estimate: 40%; at least 2.0-fold (0.30 log units) between middle value and limit.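

In this assay compound 3 gives > 10 ug/mL, which is a limit of the assay and not a number. Ethoxymethyl in place of methoxycarbonyl on this aromatic carbon gives an at least 7.6-fold higher number from compound 1 to compound 3 (0.88 log units; beyond the scatter), and since ethoxymethyl carries no hydrogen-bond donor, as methoxycarbonyl carries none, the lack of a donor at this carbon is not enough on its own to keep the number seen with compound 1. The step between compound 2 and compound 3 cannot be read, as both values are limits: the limit of > 10 ug/mL in this assay, at which 2 of the 3 values shown sit.

From the compounds shown here alone, it remains open how far compound 2 and compound 3 lie past the end of the tested range, so methylcarbamoyl and ethoxymethyl cannot be put in any order. Also open, going by these compounds, is whether the number of compound 1 depends on the carbonyl, on the methoxy part of the ester or on both, which a carboxylic acid, an ethyl ester or a hydroxymethyl group on the same carbon would help to separate.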